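Swapping the aryl group of compound 1 for a furan ring

A few compounds are considered here, and "the series" means these few. Any claim that something is new, unique, unknown or untested is made for them only; others in the source may bear on it.

Compound 1 `COC1=C(C)C(=O)/C(=C(O)/C=C/c2ccccc2OC)C(=O)C1(C)C` is one of three compounds that share a core and differ only in the aromatic group on the chain. In a functional assay on A-431 cells (Homo sapiens) for cytotoxicity (on this read-out higher numbers stand for an effect only at larger amounts of compound and lower numbers for an effect already at smaller amounts), compound 1 gives 6.6 ug/mL, the second highest of the three numbers. Compound 2 `COC1=C(C)C(=O)/C(=C(O)/C=C/c2ccc(O)cc2)C(=O)C1(C)C` gives 14.9 ug/mL in this assay, and compound 3 `C=Cc1ccccc1/C=C/C(O)=C1/C(=O)C(C)=C(OC)C(C)(C)C1=O` gives 2.6 ug/mL. The swap to a 4-hydroxyphenyl group gave a 2.3-fold higher number from compound 1 to compound 2 (0.35 log units; beyond the scatter), while the swap of methoxy for vinyl on the aromatic carbon gave a 2.5-fold lower number from compound 1 to compound 3 (0.40 log units; beyond the scatter); the two aryl groups compared directly gave a 5.7-fold lower number from compound 2 to compound 3 (0.76 log units; beyond the scatter).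

Compound 4 `COC1=C(C)C(=O)/C(=C(O)/C=C/c2ccco2)C(=O)C1(C)C` carries a different aromatic group: furan-2-yl in place of 2-methoxyphenyl on a double-bonded chain carbon bound to a double-bonded chain carbon. Among the measured compounds shown here, no measured step replaces a six-membered aromatic ring with a five-membered one, so the aryl swaps above are the only guide, and each moved the number modestly in one direction or the other. The number for compound 4 is therefore expected to stay close to that of compound 1, with a 1.2-fold higher number from compound 1 to compound 4 (0.08 log units; within the scatter) as the estimated step. Compound 4 is estimated at 8 ug/mL, within a range from 3 ug/mL to 20 ug/mL.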

Compound 4, concentration for half-maximal effect: 14.7 ug/mL
Beside the measured number, compound 4's estimate is 1.8-fold (0.26 log units) below it; the range from low to high includes it.
By their numbers in this assay, from the lowest: compound 3; then compound 1; then compounds 4 and 2 (each within the scatter of the next).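

Among the compounds shown here, the furan-2-yl group is the first five-membered aromatic ring at this place on the chain, and in this assay it gives a 2.2-fold higher number from compound 1 to compound 4 (0.35 log units; beyond the scatter), so a ring with fewer heavy atoms does not keep the number of the 2-methoxyphenyl group. Against the 2-vinylphenyl group, the same swap gives a 5.7-fold higher number from compound 3 to compound 4 (0.75 log units; beyond the scatter), while against the 4-hydroxyphenyl group it gives a 1.0-fold lower number from compound 2 to compound 4 (0.01 log units; within the scatter), so two quite different aromatic rings cannot be told apart here. No available measurement explains these shifts.

On these data alone, it remains open whether thiophene, which has sulfur in place of the furan oxygen, would give a number like that of furan-2-yl. As far as these compounds go, it is also open how a non-aromatic group, such as cyclohexyl or a simple alkyl chain, would behave at this place.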